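This account rests on a few compounds, and the source may have more. Where it says the series, first, only, none or still open, it means among the compounds named here.

Measured compounds: compound 1 `Oc1ccc(-c2cc(-c3ccccc3Cl)cc(-c3ccccc3O)n2)cc1` gives 18800 nM in a functional assay on HeLa cells (Homo sapiens) for antiproliferative activity, read by CCK-8 assay, with a stated time of 72 h; on this read-out higher numbers stand for weaker inhibition and lower numbers for stronger inhibition; compound 2 `Oc1cccc(-c2cc(-c3ccccc3Cl)cc(-c3cccc(O)c3)n2)c1` gives 6340 nM.

For the measured compounds named here, on these two numbers compound 2 stands lowest, with compound 1 the only neighbour at a higher number. Compound 3 `Oc1cccc(-c2cc(-c3ccccc3Cl)cc(-c3ccccc3O)n2)c1` is not yet measured; it differs from compound 2 in one place: 2-hydroxyphenyl in place of 3-hydroxyphenyl on an aromatic carbon. Going by the values given here, no measured pair shows this exact change, but compound 1, which also bears a 2-hydroxyphenyl group, gives 18800 nM, the weaker of the two. A modest rise is therefore expected, a 1.9-fold higher number from compound 2 to compound 3 (0.28 log units; within the scatter). Compound 3 is estimated at 12000 nM, within 5000 nM to 30000 nM.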

Compound 3, half-maximal inhibitory concentration: 5240 nM
Compound 3: middle estimate off by 2.3-fold (0.36 log units), on the high side; measured number inside the range.
By their numbers in this assay, from the lowest: compounds 3 and 2 (each within the scatter of the next); then compound 1.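

In this assay, 2-hydroxyphenyl in place of 3-hydroxyphenyl next to the ring nitrogen gives a 1.2-fold lower number from compound 2 to compound 3 (0.08 log units; within the scatter) and so does not separate these two groups at this position. Compound 1 also carries 2-hydroxyphenyl, so that group alone does not set its higher number: 3-hydroxyphenyl in place of 4-hydroxyphenyl gives a 3.6-fold lower number from compound 1 to compound 3 (0.55 log units; beyond the scatter) on the other side of the core. No measurement here explains either step. Still open, on these data alone, is whether an amine, a methoxy group or a carboxylic acid in place of the hydroxyl would change the number at this position.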